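Aryl Exchange on the Shared Core: Permeability Outlook for Compound 3

The source may report more compounds than this note shows. Statements on the series, on what has been measured and on what is new or still open speak of the compounds shown alone.

Two compounds from this series have been run in a physicochemical assay for permeability, using PAMPA; on this read-out higher numbers stand for higher permeability and lower numbers for lower permeability. Compound 1 `Cc1ccccc1-c1nc(CN2CCC(C(=O)NCCCN3CCC(C)(C)CC3)CC2)c(C)o1` gives 241 10^-6 cm/s in this assay. Compound 2 `Cc1oc(-c2ccc(Cl)cc2)nc1CN1CCC(C(=O)NCCCN2C[C@H](C)C[C@H](C)C2)CC1` is reported in this assay only as > 635 10^-6 cm/s, which is a limit of the measurement rather than a number. The evidence so far therefore amounts to the limit of > 635 10^-6 cm/s in this assay, at which 1 of the 2 values shown sits, and compound 2 stands at the top of what this assay can resolve, with no exact figure to place it against compound 1.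

Compound 3 `Cc1ccc(-c2nc(CN3CCC(C(=O)NCCCN4C[C@H](C)C[C@H](C)C4)CC3)c(C)o2)c(C)c1` differs from compound 2 in a single place: 2,4-dimethylphenyl in place of 4-chlorophenyl on an aromatic carbon. The two compounds share every other part of the structure, including the amide-linked chain and the dimethyl-substituted saturated ring.

Among the compounds with values here, no pair of measured compounds that differ in one place is available, so there is no measured step to lean on. Given that compound 2 already sits at the limit, the step from compound 2 to compound 3 is expected to be small and not beyond the usual scatter, that is an at least 1.2-fold lower number from compound 2 to compound 3 (0.10 log units; that floor lies within the scatter). Compound 3 is accordingly expected to give about 500 10^-6 cm/s in this assay, within a range from 230 10^-6 cm/s to 700 10^-6 cm/s, with a fair chance that it too is reported only as a limit.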

Compound 3, apparent permeability: 353 10^-6 cm/s
Estimate against measurement, compound 3: 1.4-fold (0.15 log units) above; the measured number falls inside the stated range.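

With the dimethyl-substituted saturated ring and the amide-linked chain held fixed, compound 3 gives 353 10^-6 cm/s in this assay as an exact number, so this aromatic carbon on the five-membered aromatic ring now has a measured value. Compound 2 is reported only as > 635 10^-6 cm/s and this is a limit, not a number. Exchanging 4-chlorophenyl for 2,4-dimethylphenyl can therefore be read only as an at least 1.7-fold lower number from compound 2 to compound 3 (0.25 log units; that floor lies within the scatter) and its full size cannot be fixed, because one end of the step is not a number: the limit of > 635 10^-6 cm/s in this assay, at which 1 of the 3 values shown sits.

The compounds shown leave open how much of this step goes with the chlorine that leaves and how much with each of the two methyl groups that enter, a question that a 4-methylphenyl or a 2-methylphenyl group on the same carbon would address. Also open, from the compounds shown here alone, is how a phenyl ring carrying a methoxy group or a nitrile at this place would read in this assay on the same shared core.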